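Homologating the alkyne substituent: oxetane moved one carbon out

The source may report more compounds than this note shows. Statements on the series, on what has been measured and on what is new or still open speak of the compounds shown alone.

Compound 2 `NC(=O)c1cc(Cl)c2c(Cl)c(C#CCO)n([C@H]3CCCNC3)c2n1` carries a hydroxymethyl group on the triple-bonded carbon of the shared core. For the measured compounds named here, in a functional assay on KG-1 cells (Homo sapiens) for antiproliferative activity (on this read-out higher numbers stand for an effect only at larger amounts of compound and lower numbers for an effect already at smaller amounts), compound 2 gives 301 nM, the higher of the two numbers measured so far. Going by the values given here, its closest relative is compound 1 `CC1(C#Cc2c(Cl)c3c(Cl)cc(C(N)=O)nc3n2[C@H]2CCCNC2)COC1`, which holds a 3-methyloxetan-3-yl group directly on the triple bond and in this assay gives 119 nM; the single change a 2.5-fold higher number from compound 1 to compound 2 (0.40 log units; beyond the scatter) is the only measured step available.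

Compound 3 `CC1(CC#Cc2c(Cl)c3c(Cl)cc(C(N)=O)nc3n2[C@H]2CCCNC2)COC1` is the unmeasured follow-up, with the change (3-methyloxetan-3-yl in place of hydroxy on a saturated chain carbon bound to a triple-bonded carbon). This swaps the same two groups as the measured step, in the reverse direction, but leaves the chain one carbon longer than in compound 1, so the measured step is a guide rather than a template. A move back toward the value of compound 1 is therefore expected, and for compound 3 in this assay the estimate is 150 nM, within 60 nM to 400 nM, corresponding to an expected step of a 2.0-fold lower number from compound 2 to compound 3 (0.30 log units; within the scatter).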

Compound 3, half-maximal effective concentration: 289 nM
Beside the measured number, compound 3's estimate is 1.9-fold (0.28 log units) below it; measured number inside the range.
By their numbers in this assay, from the lowest: compound 1; then compounds 3 and 2 (each within the scatter of the next).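

In this assay, putting 3-methyloxetan-3-yl in place of hydroxy on a saturated chain carbon bound to a triple-bonded carbon gives a 1.0-fold lower number from compound 2 to compound 3 (0.02 log units; within the scatter) and so leaves the number unchanged within the scatter, even though five heavy atoms and a four-membered ring replace a single heavy atom and the hydrogen-bond donor is lost. The step of a 2.4-fold higher number from compound 1 to compound 3 (0.39 log units; beyond the scatter) shows that the same oxetane group does not give the same number at both sites: the lower number goes with the group sitting directly on the triple-bonded carbon. No measurement here offers an explanation for this difference.

On these data alone, whether an amine or a carboxylic acid on the same chain carbon would also leave the number unchanged remains open. So does the effect of a longer chain between the triple bond and the oxetane.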